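Fluoro in place of methoxy: next step in the series

The source may report more compounds than this note shows. Statements on the series, on what has been measured and on what is new or still open speak of the compounds shown alone.

Three measured compounds share one core. Compound 1 `Fc1cccc(-c2n[nH]cc2N2CCCNCC2)c1` gives 656 nM in an assay on isolated protein for binding affinity to 5-hydroxytryptamine receptor 3A (Homo sapiens) (a higher number here means a weaker inhibitor, a lower number a stronger inhibitor), compound 2 `COc1ccc(-c2n[nH]cc2N2CCCNCC2)cc1` gives 1230 nM, and compound 3 `COc1cccc(-c2n[nH]cc2N2CCNCC2)c1` gives 2100 nM. Compound 3 carries the highest number of the three: its gap to compound 2 lies within the scatter, whereas compound 1 stands beyond it with a clearly lower number. Among the measured compounds shown here, no pair among them differs in one place only, so no single step is on hand. Compound 4 `Fc1cccc(-c2n[nH]cc2N2CCNCC2)c1` is compound 3 with fluoro in place of methoxy on an aromatic carbon. The step is expected as a 2.1-fold lower number from compound 3 to compound 4 (0.32 log units; beyond the scatter), a modest move to a lower number that may not clear the scatter, because compound 1 gives 656 nM. For compound 4 the estimate in this assay is 1000 nM, ranging from 400 nM to 2500 nM.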

Compound 4, inhibition constant: > 10000 nM
Compound 4: no number, only a limit (the forecaster's own chance of this, stated with the estimate: 2%); middle value at least 10-fold (1.00 log units) away from the limit.
By their numbers in this assay, from the lowest: compounds 1, 2 and 3 (each within the scatter of the next, the first and the last beyond it). At a limit, above all of these: compound 4.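

In this assay, fluoro in place of methoxy on this aromatic carbon, meta to a large group, costs clear affinity: an at least 4.7-fold higher number from compound 3 to compound 4 (0.67 log units; beyond the scatter). Compound 4 gives > 10000 nM, which is a limit of the assay and not a number. Fluoro stands on the same carbon in compound 4 and in compound 1, and compound 1 gives 656 nM, so fluoro at this place does not by itself rule out a measurable number on every core shown.

Open, from the compounds shown here alone, is whether hydroxyl, chloro or methyl on this carbon would keep a measurable number on the core of compound 3. Going by these compounds, the true size of the step also stays open, since only a limit is available for compound 4.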